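Moving a Methyl on a Thiophene Amide

The source may report more compounds than this note shows. Statements on the series, on what has been measured and on what is new or still open speak of the compounds shown alone.

Of the compounds shown here, three of a shared core have been measured in an assay on HEK293 cells for agonist activity at transient receptor potential cation channel subfamily M member 8 (Homo sapiens), read by fluorescence and calcium flux, with a stated time of 15 min; a higher number here means that more compound is needed for the effect, a lower number that less compound is needed. Compound 1 `CCN(Cc1ccc(C)s1)C(=O)COc1ccc(C)cc1` gives 178 nM in this assay, and among the three numbers it stands second highest. Its nearest neighbour is compound 3 `Cc1ccc(OCC(=O)N(Cc2cccs2)c2ccn(C)n2)cc1`, which in this assay gives 855 nM, a higher number beyond the usual scatter. Far from both lies compound 2 `O=C(COc1ccc2c(c1)CCC2)N(Cc1cccs1)c1ccn[nH]1`, which in this assay gives 0.001 nM, a vastly lower number.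

The next compound, compound 4 `CCN(C(=O)COc1ccc(C)cc1)C(C)c1cccs1`, is built from the same atoms as compound 1, joined differently: 1-(thiophen-2-yl)ethyl in place of (5-methylthiophen-2-yl)methyl on an amide-type nitrogen. For the measured compounds named here, no measured pair shows the effect of this particular rearrangement, so the account can only expect. Since the methyl is merely relocated on the same amide-type nitrogen substituent, the expected step from compound 1 to compound 4 in this assay, a 1.5-fold higher number from compound 1 to compound 4 (0.16 log units; within the scatter), is small, with a slight lean toward a higher number. Compound 4 is therefore expected to give about 260 nM in this assay, within a range of 60 nM to 1100 nM.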

Compound 4, half-maximal effective concentration: "not active" (no number reported)
For compound 4 the study gives words and no number, and the estimate cannot be compared.
By their numbers in this assay, from the lowest: compound 2; then compound 1; then compound 3.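

In this assay, for the compounds shown here, compound 4 is reported only as "not active", without a number, so no step from compound 1 to compound 4 can be read. Nothing shown bears on the reason for this result. The compounds shown leave open how far compound 4 lies from compound 1 in number.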